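A few compounds are considered here, and "the series" means these few. Any claim that something is new, unique, unknown or untested is made for them only; others in the source may bear on it.

In a functional assay on HeLa cells (Homo sapiens) for antiproliferative activity, read by MTT assay, with a stated time of 48 h (on this read-out lower numbers stand for stronger inhibition and higher numbers for weaker inhibition), compound 1 `COc1ccc(C(=O)c2ccc(OC)c3c2C=CC(C)(C)O3)c(NC(=O)CBr)c1` gives 3680 nM, within the scatter of compound 3 `CCNCC(=O)Nc1cc(OC)ccc1C(=O)c1ccc(OC)c2c1OC(C)(C)C=C2` at 2690 nM. Compound 2 `COc1ccc(C(=O)c2ccc3c(c2)C=CC(C)(C)O3)c(NC(=O)CO)c1`, at 240 nM, stands well below both. The next compound is compound 4 `COc1ccc(C(=O)c2ccc(OC)c3c2C=CC(C)(C)O3)c(NC(=O)CN(C)C)c1`, with dimethylamino in place of bromo on a saturated chain carbon bound to a carbonyl carbon. Going by the values given here, no measured pair isolates this change. The closest guide is compound 3 at 2690 nM, which also has an amino group on that chain carbon and sits level with compound 1 at 3680 nM, so no step beyond the scatter is expected. The estimated step is a 1.5-fold lower number from compound 1 to compound 4 (0.17 log units; within the scatter), slightly downward if real. Compound 4 is expected at 2500 nM, with an estimated range of 800 nM to 7000 nM.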

Compound 4, half-maximal inhibitory concentration: 3620 nM
Beside the measured number, compound 4's estimate is 1.4-fold (0.16 log units) below it; the range from low to high includes it.
By their numbers in this assay, from the lowest: compound 2; then compounds 3, 4 and 1 (each within the scatter of the next).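

In this assay, going by these compounds alone, the dimethylamino for bromo exchange on a saturated chain carbon bound to a carbonyl carbon gives a 1.0-fold lower number from compound 1 to compound 4 (0.01 log units; within the scatter) and is the first single-place change read at this position. Going from bromo, with 1 heavy atom, to dimethylamino, with 3 heavy atoms, therefore leaves the number level on the core of compound 1. No evidence on hand bears on why this step is flat.
As far as these compounds go, whether a carboxylic acid, a morpholine ring or a longer chain at this place would shift the number remains open.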